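Oral Exposure Across Stereoisomers of a Bis-Carbamate Series

The source may report more compounds than this note shows. Statements on the series, on what has been measured and on what is new or still open speak of the compounds shown alone.

Measured compounds:
- compound 1 `COC(=O)N[C@H](C(=O)N1CCC[C@H]1C(=O)Nc1ccc([C@H]2CC[C@H](c3ccc(NC(=O)[C@@H]4CCCN4C(=O)[C@@H](NC(=O)OC)C(C)C)cc3)N2c2ccc(C(F)(F)F)cc2)cc1)C(C)C`: 13%
- compound 2 `COC(=O)N[C@H](C(=O)N1CCC[C@H]1C(=O)Nc1ccc([C@@H]2CC[C@@H](c3ccc(NC(=O)[C@@H]4CCCN4C(=O)[C@@H](NC(=O)OC)C(C)C)cc3)N2c2ccc(F)cc2)cc1)C(C)C`: 22%

Of the compounds shown here, two have been tested in an ADME assay on the whole organism for pharmacokinetics, with Rattus norvegicus as the target, at a dose of 3 mg/kg by the oral route; a lower number here means that a smaller share of the oral dose reaches the circulation, a higher number that a larger share of the oral dose reaches the circulation. Compound 2 gives 22%, the higher of the two numbers, and compound 1 gives 13%, which sits within the scatter of that figure, so the two cannot be ranked against each other.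

Compound 3 `COC(=O)N[C@H](C(=O)N1CCC[C@H]1C(=O)Nc1ccc([C@H]2CC[C@H](c3ccc(NC(=O)[C@@H]4CCCN4C(=O)[C@@H](NC(=O)OC)C(C)C)cc3)N2c2ccc(F)cc2)cc1)C(C)C` has not yet been measured. It is related to compound 2 as follows: the two compounds have the same atoms and bonds and differ only in configuration as drawn: 2 of 6 stereo elements differ; a stereocentre at a saturated ring carbon is drawn S in compound 2 and R in compound 3; a stereocentre at a saturated ring carbon is drawn S in compound 2 and R in compound 3. Among the compounds with values here, no step between two measured compounds is available to calibrate such a change in configuration, so the expectation rests on the narrow spread seen so far. Compound 3 is expected to show no movement beyond the scatter, with a step of a number 7 percentage points lower from compound 2 to compound 3 (within the scatter) from compound 2 anticipated. The estimate for compound 3 in this assay is 15%, with a range from 5% to 30%.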

Compound 3, oral bioavailability: 22%
Beside the measured number, compound 3's estimate is 7 percentage points below it; measured number inside the range.
By their numbers in this assay, from the lowest: compounds 1, 2 and 3 (each within the scatter of the next).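

In this assay, within the data shown here, inverting the two saturated ring carbons gives no change at the digits printed from compound 2 to compound 3 (within the scatter), so the first readable change in configuration cannot be told from the scatter. With the drawn configuration held the same, fluoro in place of trifluoromethyl on an aromatic carbon gives a number 9 percentage points higher from compound 1 to compound 3 (within the scatter), so this swap also stays inside the scatter and the two groups cannot be ranked here. The configuration comparison is clean on one count: the fact that compounds 2 and 3 differ only in the configuration as drawn.

From the compounds shown here alone, whether the same inversion would read the same with trifluoromethyl in place of fluoro remains open, as does the effect of the remaining stereo elements. The compounds shown also say nothing about how a chloro, methoxy or nitrile group on that aromatic carbon would read in this assay.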